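The source may hold more compounds than are shown below. What is called first, only, known or untested is meant among the compounds shown, and "the series" means these compounds.

Compound 1 `O=C(c1cccnc1)c1ccccc1O` and compound 2 `O=C(c1cccnc1)c1cccc(Cl)c1O` share one core, and in a functional assay on Hep cells (Homo sapiens) for cytotoxicity, read by sulforhodamine B assay, with a stated time of 48 h (a higher number here means a weaker inhibitor, a lower number a stronger inhibitor), compound 1 gives 31000 nM. In this assay compound 2 gives 28000 nM. The change between them is hydrogen in place of chloro on an aromatic carbon, and the step of a 1.1-fold higher number from compound 2 to compound 1 (0.04 log units; within the scatter) is small. Compound 3 `C=CCOc1ccc(Cl)cc1C(=O)c1cccnc1` carries a different core, and the difference between the two cores is not broken down here. In this assay compound 3 gives only a limit, > 100000 nM, and the reading the limit of > 100000 nM in this assay, at which 1 of the 3 values shown sits, tells nothing more than that. Compound 4 `C=CCOc1ccccc1C(=O)c1cccnc1` has not yet been measured in this assay. It differs from compound 3 by hydrogen in place of chloro on an aromatic carbon, the same kind of change as from compound 2 to compound 1, though the place is not the same: in the earlier pair the carbon was ortho to a hydroxy group, here it is para to an allyloxy group. The step that the limit leaves unreadable from compound 3 to compound 4 is expected to be small, because the earlier step of a 1.1-fold higher number from compound 2 to compound 1 (0.04 log units; within the scatter) was within the scatter. Compound 4 is therefore estimated at 120000 nM in this assay, between 50000 nM and 300000 nM, most likely again reported only as a limit.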

Compound 4, half-maximal inhibitory concentration: > 100000 nM
Compound 4: only a limit was reported; the forecaster's own chance of this, stated with the estimate: 70%; the middle value is on the limit's open side.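

In this assay, hydrogen in place of chloro on an aromatic carbon gives a 1.1-fold higher number from compound 2 to compound 1 (0.04 log units; within the scatter) on the core of compound 1, but the same kind of change on the core of compound 3 cannot be read, because compound 3 and compound 4 both stand only as limits: the limit of > 100000 nM in this assay, at which 2 of the 4 values shown sit. The series therefore does not show that this change carries over from one core to the other, nor does it show that it fails to. Among the compounds shown here, the one new step that can be read is a different change, allyl in place of hydrogen on an oxygen on an aromatic ring, and it gives an at least 3.2-fold higher number from compound 1 to compound 4 (0.50 log units; beyond the scatter) for this single pair.

The compounds shown leave open how a group other than allyl on that oxygen, such as a shorter or longer chain, an amine or a carboxylic acid, would read in this assay. They also leave open whether chloro has any effect on the allyl-bearing core at values that can be read.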